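Benzyl replacements at the shared core: toward an imidazolylmethyl analogue

The source may report more compounds than this note shows. Statements on the series, on what has been measured and on what is new or still open speak of the compounds shown alone.

Measured so far:
compound 1, `Cc1cc(-c2c(F)cc3c(=O)ccn(C4CC4)c3c2F)cc(C)n1`, 15000 nM
compound 2, `COc1ccc(Cc2cn(C3CC3)c3c(F)c(-c4cc(C)nc(C)c4)c(F)cc3c2=O)cc1`, 21000 nM
compound 3, `Cc1cc(-c2c(F)cc3c(=O)c(Cc4ccc(O)cc4)cn(C4CC4)c3c2F)cc(C)n1`, 1500 nM

In a functional assay on P388 cells (Mus musculus) for cytotoxicity (on this read-out lower numbers stand for stronger inhibition and higher numbers for weaker inhibition), compound 2 gives 21000 nM, the highest of the three numbers; it sits close to compound 1, with a 1.4-fold higher number from compound 1 to compound 2 (0.15 log units; within the scatter), while its distance to compound 3 is considerable, with a 14-fold lower number from compound 2 to compound 3 (1.15 log units; beyond the scatter). Compound 4, `Cc1cc(-c2c(F)cc3c(=O)c(Cc4c[nH]cn4)cn(C4CC4)c3c2F)cc(C)n1`, has not been measured. Its difference from compound 2 is 1H-imidazol-4-yl in place of 4-methoxyphenyl on a saturated chain carbon bound to an aromatic carbon.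

For the measured compounds named here, two measured steps bear on this. The step from compound 1 to compound 2, a 1.4-fold higher number from compound 1 to compound 2 (0.15 log units; within the scatter), shows that attaching a 4-methoxybenzyl at the aromatic carbon leaves the number where it was. The step from compound 2 to compound 3, a 14-fold lower number from compound 2 to compound 3 (1.15 log units; beyond the scatter), shows that trading the methyl on the ring oxygen for hydrogen, so that the attached group gains a hydrogen-bond donor, lowers the number markedly; the step from compound 1 to compound 3, a 10-fold lower number from compound 1 to compound 3 (1.00 log units; beyond the scatter), agrees. Going by the values given here, the group entering in compound 4 likewise brings one hydrogen-bond donor and one acceptor, though on a smaller five-membered ring with two hetero atoms, so no direct measured analogue exists. A lower number is therefore expected for compound 4, probably less extreme than that of compound 3 given the ring change, with a 5.3-fold lower number from compound 2 to compound 4 (0.72 log units; beyond the scatter). The estimate for compound 4 in this assay is 4000 nM, in the range 1200 nM to 14000 nM.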

Compound 4, half-maximal inhibitory concentration: 390 nM
Compound 4: the middle estimate sits 10-fold (1.01 log units) above what was measured, and the stated range ends above it.
By their numbers in this assay, from the lowest: compound 4; then compound 3; then compounds 1 and 2 (each within the scatter of the next).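

The (1H-imidazol-4-yl)methyl group gives the strongest result so far at this aromatic carbon in this assay, with a 38-fold lower number from compound 1 to compound 4 (1.59 log units; beyond the scatter) on the shared core. A six-membered carbon ring is not needed for the gain: 1H-imidazol-4-yl in place of 4-hydroxyphenyl goes further, with a 3.8-fold lower number from compound 3 to compound 4 (0.59 log units; beyond the scatter), although the smaller ring has only 5 heavy atoms. Against the 4-methoxyphenyl group the change is larger still, with a 54-fold lower number from compound 2 to compound 4 (1.73 log units; beyond the scatter), so the two groups on the chain carbon that carry a hydrogen-bond donor, in compound 3 and compound 4, both stand clear of compound 1, while compound 2, which has no such donor, does not.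

From the compounds shown here alone, whether a longer chain carrying the 1H-imidazol-4-yl, or a carboxylic acid or an amine in its place, keeps the number this low stays open. The same holds for a pyrazole or a triazole ring on the chain carbon. No supporting data are at hand to explain the order of these compounds.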